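A few compounds are considered here, and "the series" means these few. Any claim that something is new, unique, unknown or untested is made for them only; others in the source may bear on it.

Measured compounds:
compound 1 `C[C@H](Nc1ncnc2[nH]cnc12)c1nn(-c2cccnc2)c2cc(F)ccc12`: 23%
compound 2 `CC(C)[C@H](Nc1ncnc2[nH]cnc12)c1nn(-c2cccnc2)c2cc(F)ccc12`: 16%
compound 3 `C[C@H](Nc1nc(N)nc2[nH]cnc12)c1nn(-c2cccnc2)c2cc(F)ccc12`: 11%

In a functional assay on HepG2 cells (Homo sapiens) for inhibition, read by sulforhodamine B assay, with a stated time of 72 h, tested at 10 uM (a higher number here means more inhibition at the concentration tested (going by the name of the read-out), a lower number less inhibition), compound 1 gives 23%, the highest of the three numbers. Compound 2 sits nearest, with a number 7 percentage points lower from compound 1 to compound 2 (within the scatter), a change that stays within the scatter. Compound 3 lies furthest, with a number 12 percentage points lower from compound 1 to compound 3 (beyond the scatter), a modest drop beyond the scatter.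

Compound 4 `C[C@H](Nc1ncnc2[nH]cnc12)c1nn(-c2ccc(C#N)cc2)c2cc(F)ccc12` is not yet measured. It differs from compound 1 in one place: 4-cyanophenyl in place of pyridin-3-yl on an aromatic nitrogen. Both measured steps alter other parts of the molecule, the chain carbon in the step to compound 2 and the fused core in the step to compound 3, so neither bears directly on the group at this aromatic nitrogen. The two known steps were small, one within the scatter and one modest, and the exchanged groups each carry a single hydrogen-bond acceptor. Compound 4 is therefore expected to change this assay by a number 3 percentage points lower from compound 1 to compound 4 (within the scatter), a step not clearly beyond the scatter, with the direction uncertain. Compound 4 is estimated at 20%, between 5% and 38%.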

Compound 4, a percentage reported as inhibition, at one concentration (the size of the read-out at that concentration, not a potency): 57%
Beside the measured number, compound 4's estimate is 37 percentage points below it; the measured number lies above the stated range.
By their numbers in this assay, from the lowest: compounds 3, 2 and 1 (each within the scatter of the next, the first and the last beyond it); then compound 4.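

The group on the aromatic nitrogen proves to be a sensitive point in this assay: a number 34 percentage points higher from compound 1 to compound 4 (beyond the scatter), a step upward, whereas the changes elsewhere on compound 1 both gave lower numbers, with a number 7 percentage points lower from compound 1 to compound 2 (within the scatter) and a number 12 percentage points lower from compound 1 to compound 3 (beyond the scatter). The counts of hydrogen-bond donors and acceptors and the net charge are the same for pyridin-3-yl and 4-cyanophenyl, so these counts do not separate the two groups; what differs is that the entering group has a six-membered aromatic ring of carbon only, a triple bond outside that ring and more heavy atoms. No measurement available here explains why this exchange has such a large effect.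

The exchange replaces the ring and adds the nitrile in a single step, so the compounds shown leave open how much of the rise belongs to each, a question that a plain phenyl or an amide in place of the nitrile would address. Going by these compounds, it also remains open whether 4-cyanophenyl keeps its effect alongside the isopropyl group of compound 2 or the amino group of compound 3, and the reading at one concentration gives no potency.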